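The compounds below may be only part of what the source reports. "The series", "measured", "known", "first", "only" and "open" are said of these compounds alone.

Compound 3, drawn as `Nc1cc(N)c2nc(-c3ccccc3)c(Sc3ccc(Cl)c(Cl)c3)nc2c1`, gives 57500 nM in a functional assay on SK-MEL-28 cells (Homo sapiens) for inhibition, read by sulforhodamine B assay, with a stated time of 48 h; on this read-out lower numbers stand for stronger inhibition of growth and higher numbers for weaker inhibition of growth. Among the numbers shown it stands highest, but its nearest neighbour, compound 1 with structure `COc1ccc(CNc2nc3cc(N)cc(N)c3nc2-c2ccccc2)cc1OC`, lies within the scatter of it: compound 1 gives 30200 nM in this assay. Compound 2, with structure `COc1ccc(Sc2nc3cc(N)cc(N)c3nc2-c2ccccc2)cc1`, is known only by a limit in this assay, where compound 2 gives < 100000 nM. Going by the values given here, the one single-point step among the measured compounds is a step that the limit leaves unreadable from compound 2 to compound 3, and its size cannot be read, as the limit of < 100000 nM in this assay, at which 1 of the 3 values shown sits, makes plain.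

Compound 4, drawn as `Nc1cc(N)c2nc(-c3ccccc3)c(Sc3ccc(F)cc3)nc2c1`, differs from compound 3 by 4-fluorophenyl in place of 3,4-dichlorophenyl on a sulfur. Among the compounds with values here, nothing measured here shows what exchanging one aryl group on the sulfur for another does in this assay, since the only such step is unreadable. The expectation for compound 4 is therefore a step of a 1.0-fold higher number from compound 3 to compound 4 (0.02 log units; within the scatter), that is, none beyond the scatter. Compound 4 is estimated at 60000 nM, within a range from 25000 nM to 150000 nM.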

Compound 4, concentration for total growth inhibition: 53700 nM
Compound 4: middle estimate off by 1.1-fold (0.05 log units), on the high side; measured number inside the range.
By their numbers in this assay, from the lowest: compounds 1, 4 and 3 (each within the scatter of the next).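

In this assay, going by these compounds alone, 4-fluorophenyl in place of 3,4-dichlorophenyl on a sulfur gives a 1.1-fold lower number from compound 3 to compound 4 (0.03 log units; within the scatter), the first step at this position whose size can be read. Within the data shown here, two aryl groups on the sulfur, one carrying two chlorines and the other one fluorine, are thus not told apart in this read-out, which the earlier compounds could not show. The steps starting from compound 2 cannot be read, because compound 2 is known only by a limit: the limit of < 100000 nM in this assay, at which 1 of the 4 values shown sits.

The compounds shown leave open whether any group on the sulfur can move the number beyond the scatter, for instance a phenyl bearing an amine or a carboxylic acid, or a butyl chain in place of the aryl group. Also open, on these data alone, is what an oxygen or an amine nitrogen in place of the sulfur would do with the 4-fluorophenyl group kept.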